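Anilide series on a shared boron-containing core: para substituent

The source may report more compounds than this note shows. Statements on the series, on what has been measured and on what is new or still open speak of the compounds shown alone.

Measured so far in a functional assay on SK-OV-3 cells (Homo sapiens) for antiproliferative activity, read by MTT assay, with a stated time of 72 h; a lower number here means a stronger inhibitor, a higher number a weaker inhibitor:
- compound 1, `CC(C)(C)NC(=O)CCc1cccc2c1B(O)OC2`: > 100000 nM
- compound 2, `O=C(CCc1cccc2c1B(O)OC2)Nc1ccc(Br)cc1`: 9200 nM
- compound 3, `O=C(CCc1cccc2c1B(O)OC2)Nc1cccc(Br)c1`: 540 nM

The value for compound 1 is a limit of this assay, not a number (the limit of > 100000 nM in this assay, at which 1 of the 3 values shown sits). Among the two numbers, compound 2 has the highest; its nearest neighbour is compound 3, and the step from compound 2 to compound 3 is a 17-fold lower number from compound 2 to compound 3 (1.23 log units; beyond the scatter). Moving from the tert-butyl amide to the anilides gave an at least 10-fold lower number from compound 1 to compound 2 (1.03 log units; beyond the scatter) and an at least 180-fold lower number from compound 1 to compound 3 (2.26 log units; beyond the scatter).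

Compound 4, `O=C(CCc1cccc2c1B(O)OC2)Nc1ccc(-c2ccccc2)cc1`, is not yet measured. Compared with compound 2 it differs as follows: phenyl in place of bromo on an aromatic carbon. For the measured compounds named here, no measured step changes the group on the aromatic carbon of the anilide; the only step that touches this part of the molecule moves the bromo from one ring carbon to another, and that step was large. The nature of the substituent in the position held by bromo in compound 2 is therefore untested, and the expected step in this assay is a 1.2-fold lower number from compound 2 to compound 4 (0.06 log units; within the scatter), with the direction open. Compound 4 is estimated at 8000 nM, with a range from 2000 nM to 40000 nM.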

Compound 4, half-maximal inhibitory concentration: 48000 nM
Beside the measured number, compound 4's estimate is 6.0-fold (0.78 log units) below it; measured number above the stated range.
By their numbers in this assay, from the lowest: compound 3; then compound 2; then compound 4. At a limit, above all of these: compound 1.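

In this assay the change from bromo to phenyl on this aromatic carbon gave a 5.2-fold higher number from compound 2 to compound 4 (0.72 log units; beyond the scatter) and so shows that the group held here, and not only its place on the anilide ring, affects the read-out. The earlier compounds shown here varied the amide substituent and the ring carbon carrying bromo, whereas this step keeps the place and exchanges one heavy atom for a six-membered aromatic ring of carbon only, with neither group bringing hydrogen-bond donors or acceptors or a net charge; at this position, the larger of these two groups gives the higher number, which is a comparison of two groups and not a trend. Nothing given here accounts for the size or direction of this step.

Going by these compounds, with only bromo and phenyl compared at this position, it remains open whether a smaller group such as fluoro, or an amine or a carboxylic acid, would lower the number or raise it further. On these data alone, it is also open whether phenyl on the ring carbon that carries bromo in compound 3 would bring a step of similar direction and size.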